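Swapping the chlorophenyl of compound 3 for a methoxyphenyl

A few compounds are considered here, and "the series" means these few. Any claim that something is new, unique, unknown or untested is made for them only; others in the source may bear on it.

Three esters share a common core and differ only in the aryl group on a double-bonded chain carbon bound to a double-bonded chain carbon. In a functional assay on the whole organism (strain Kunming) with Mus musculus as the target, with a stated time of 0.5 h, at a dose of 300 mg/kg by the intraperitoneal route (on this read-out higher numbers stand for a weaker effect at the one dose given and lower numbers for a stronger effect), compound 1 `COc1cc(OC)c(OC)cc1/C=C/COC(=O)/C=C/c1ccc(OC)c(OC)c1` gives 0%, compound 2 `COc1cc(OC)c(OC)cc1/C=C/COC(=O)/C=C/c1ccc(F)cc1` gives 0%, and compound 3 `COc1cc(OC)c(OC)cc1/C=C/COC(=O)/C=C/c1ccc(Cl)cc1` gives 25%. Compound 3 thus holds the highest number of the three, with a number 25 percentage points higher from compound 1 to compound 3 (beyond the scatter) and a number 25 percentage points higher from compound 2 to compound 3 (beyond the scatter), while no change at the digits printed from compound 1 to compound 2 (within the scatter). Compound 4 `COc1cccc(/C=C/C(=O)OC/C=C/c2cc(OC)c(OC)cc2OC)c1` is the next member: 3-methoxyphenyl in place of 4-chlorophenyl on a double-bonded chain carbon bound to a double-bonded chain carbon. Among the compounds with values here, no measured step exchanges a halogen for a methoxy group, but compound 1 carries two methoxy groups on its aryl ring and sits at the low end of the series, and the only step that moved the number beyond the scatter involved the chloro group that compound 4 gives up. The expectation is therefore a drop for compound 4 in this assay, a number 17 percentage points lower from compound 3 to compound 4 (beyond the scatter). Compound 4 is estimated at 8%, with a likely range from 0% to 30%.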

Compound 4, a percentage reported as activity, at one dose (the size of the read-out at that dose, not a potency): 50%
Compound 4: the middle estimate sits 42 percentage points below what was measured; measured number outside the range, above it.
By their numbers in this assay, from the lowest: compounds 1 and 2 (each within the scatter of the next); then compound 3; then compound 4.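

In this assay the aryl group at this place moves the number further than the exchange of one halogen for another did, with a number 25 percentage points higher from compound 3 to compound 4 (beyond the scatter) and a number 50 percentage points higher from compound 2 to compound 4 (beyond the scatter) for 3-methoxyphenyl in place of the two halogen-bearing rings. A methoxy group on this ring does not by itself keep the number low: a number 50 percentage points higher from compound 1 to compound 4 (beyond the scatter) goes with hydrogen in place of methoxy on an aromatic carbon, so the 3,4-dimethoxyphenyl and 3-methoxyphenyl rings read far apart. Nothing measured here accounts for these steps.

The compounds shown leave open whether the number of methoxy groups on the ring or the place of the one that remains sets this step. Going by these compounds, how a ring carrying an amine or a carboxylic acid would read at this place also stays open.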